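The source may hold more compounds than are shown below. What is called first, only, known or untested is meant among the compounds shown, and "the series" means these compounds.

Two compounds measured in an assay on HEK293 cells for displacement of a labelled ligand from NPC1-like intracellular cholesterol transporter 1 (Homo sapiens) (on this read-out higher numbers stand for weaker inhibition and lower numbers for stronger inhibition), share one core and differ at two places. Compound 1 `O=C(CN1CN(c2ccccc2)C2(CCN(C(=O)c3ccc(C4CCCCC4)cc3)CC2)C1=O)NCCO` gives 2000 nM in this assay. Compound 2 `CC(C)(C)c1ccc(C(=O)N2CCC3(CC2)C(=O)N(CC(=O)NCCC(=O)O)CN3c2ccccc2)cc1` gives 11400 nM, the higher of the two numbers and therefore the weaker of the two on this read-out; the gap to compound 1 is beyond the usual scatter. Compound 1 and compound 2 differ in more than one place, so nothing can be said about which of the two differences carries the gap.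

Compound 3 `CC(C)(C)c1ccc(C(=O)N2CCC3(CC2)C(=O)N(CC(=O)NCCCCNS(C)(=O)=O)CN3c2ccccc2)cc1` has not been measured. It differs from compound 2 in one place: 2-(methanesulfonamido)ethyl in place of carboxy on a saturated chain carbon, two bonds along the chain from an amide-type nitrogen. Within the shown numbers nothing tells how such a change behaves, so the expectation rests on the change alone. Compound 3 is expected to give a somewhat lower number than compound 2 in this assay, with the step of a 2.5-fold lower number from compound 2 to compound 3 (0.40 log units; beyond the scatter) estimated as a modest improvement, close to the edge of the usual scatter and not clearly beyond it. The estimate for compound 3 is 4500 nM, with a range from 1500 nM to 14000 nM.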

Compound 3, half-maximal inhibitory concentration: 4500 nM
Beside the measured number, compound 3's estimate shows no gap at the digits printed; the measured number falls inside the stated range.
By their numbers in this assay, from the lowest: compound 1; then compound 3; then compound 2.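

This is the first pair shown that differs in only one place, so a gap can be tied to a single change: in this assay, putting 2-(methanesulfonamido)ethyl in place of carboxy on a saturated chain carbon, two bonds along the chain from an amide-type nitrogen, gives a 2.5-fold lower number from compound 2 to compound 3 (0.40 log units; beyond the scatter) as a modest step. The carboxy group is therefore not required at this place for inhibition in this assay to be kept, and a group of 7 heavy atoms is accepted there in place of one of 3. Nothing measured here accounts for the step.

The change lengthens the chain and replaces its end group at the same time, so the compounds shown do not separate these two effects; a plain butyl chain or a 2-aminoethyl group at this place would help to tell them apart. From the compounds shown here alone, it also remains open whether the same change would give a step of similar size with the cyclohexyl group of compound 1 in the molecule.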